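Swapping an ester chain for a dimethylphenyl group

The source may report more compounds than this note shows. Statements on the series, on what has been measured and on what is new or still open speak of the compounds shown alone.

Three compounds built on one shared core have been run in an ADME assay on Huh-7 cells (Homo sapiens) for cytotoxicity; on this read-out lower numbers stand for higher toxicity in this test and higher numbers for lower toxicity in this test. Compound 1 `Cc1ccccc1-c1nn(-c2ccc(F)cc2F)cc1CNCCN(C)C` carries a difluorophenyl group on the ring nitrogen. In this assay compound 1 gives > 20000 nM, which is a limit of the assay rather than a number. Compound 3 `Cc1ccccc1-c1nn(-c2ccc(F)cc2F)cc1CNCc1ccncc1` is its single-change partner, and in this assay compound 3 gives > 20000 nM, again a limit. Within the data shown here, the only step within the measured set, a step that the two limits leave unreadable from compound 1 to compound 3, therefore cannot be read in size.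

Compound 2 `CCOC(=O)Cn1cc(CNCCN2CCN(C)CC2)c(-c2ccccc2C)n1` carries a (ethoxycarbonyl)methyl group on the ring nitrogen and a longer chain on the amine. In this assay compound 2 gives > 20000 nM, once more a limit and not a number. Compound 2 thus stands where the other two stand, at the limit of > 20000 nM in this assay, at which 3 of the 3 values shown sit, with no numerical value anywhere in the set.

Compound 4 `Cc1ccc(-n2cc(CNCCN3CCN(C)CC3)c(-c3ccccc3C)n2)c(C)c1` differs from compound 2 by 2,4-dimethylphenyl in place of (ethoxycarbonyl)methyl on an aromatic nitrogen. Among the measured compounds shown here, no measured step bears on this change, and the single step available is unreadable, so no shift beyond the scatter is expected. The step from compound 2 to compound 4 is estimated as a step that the limit leaves unreadable from compound 2 to compound 4. Compound 4 is expected to give 30000 nM, within 15000 nM to 80000 nM, most likely again as a limit.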

Compound 4, half-maximal cytotoxic concentration: > 20000 nM
Compound 4 ended at the assay's limit; the forecaster's own chance of this, stated with the estimate: 80%; the middle value is on the limit's open side.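

Among these compounds, the step between compound 2 and compound 4 cannot be read in size, so no new step comes from this result. Both compounds sit at the same limit of this assay, and that limit is not a number: the limit of > 20000 nM in this assay, at which 4 of the 4 values shown sit.

The compounds shown leave open how far 2,4-dimethylphenyl and (ethoxycarbonyl)methyl actually differ in this assay, and whether any compound on this core gives a numerical value there.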